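Two Chlorobenzyl Groups on One Shared Core

The source may hold more compounds than are shown below. What is called first, only, known or untested is meant among the compounds shown, and "the series" means these compounds.

Compound 2 `COc1ccc(C2N=C(SCc3ccccc3Cl)NC(C)=C2C(=O)Nc2ccc(Br)cc2)cc1` and compound 1 `CC1=C(C(=O)Nc2ccc(Br)cc2)C(c2ccc(Cl)cc2Cl)N=C(SCc2cccc(Cl)c2)N1` share a core. In a functional assay on the whole organism (artery, strain albino) with Rattus norvegicus as the target, with a stated time of 15 min, at a dose of 10 mg/kg by the oral route (a higher number here means more inhibition at the dose given (going by the name of the read-out), a lower number less inhibition), compound 2 gives 3.1%, and compound 1 gives 1.5%; these two numbers lie within the scatter of each other, so the inhibition in this assay is level between them. Compound 3 `COc1ccc(C2N=C(SCc3cccc(Cl)c3)NC(C)=C2C(=O)Nc2ccc(Br)cc2)cc1` differs from compound 2 in one place: 3-chlorophenyl in place of 2-chlorophenyl on a saturated chain carbon bound to a sulfur. For the measured compounds named here, no step between measured compounds is known. Since compound 1, which already carries a (3-chlorobenzyl)sulfanyl group, gives 1.5%, the expected step of a number 0.6 percentage points lower from compound 2 to compound 3 (within the scatter) is no change beyond the scatter. Compound 3 is estimated to give 2.5%, with a range from 0% to 12%.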

Compound 3, a percentage reported as inhibition, in the whole organism at one dose (the size of the read-out at that dose, not a potency): 3.1%
For compound 3 the middle estimate is 0.6 percentage points below the measured one; low and high end bracket the measured number.
By their numbers in this assay, from the lowest: compounds 1, 2 and 3 (each within the scatter of the next).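

In this assay, 3-chlorophenyl in place of 2-chlorophenyl gives no change at the digits printed from compound 2 to compound 3 (within the scatter), so on this saturated chain carbon bound to a sulfur, the two groups read alike. Putting 4-methoxyphenyl in place of 2,4-dichlorophenyl on a saturated ring carbon gives a number 1.6 percentage points higher from compound 1 to compound 3 (within the scatter), so that second place shows no separation either. Nothing measured here speaks to why these numbers sit so close.

On these data alone, whether 4-chlorophenyl on that chain carbon would read the same stays open. So does whether an amine or a carboxylic acid there would give more inhibition.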